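Chloro to methyl on the fused core of compound 1

A few compounds are considered here, and "the series" means these few. Any claim that something is new, unique, unknown or untested is made for them only; others in the source may bear on it.

Among the compounds with values here, compound 1 `O=C1Cc2ccc(Cl)cc2C=C1C(=O)N[C@@H]1O[C@H](CO)[C@@H](O)[C@H](O)[C@H]1O` and compound 2 `CC(C)(C)c1ccc(/C=C/C(=O)N[C@@H]2O[C@H](CO)[C@@H](O)[C@H](O)[C@H]2O)cc1` are the two measured members. In a physicochemical assay for lipophilicity, measured as octanol-water partition (on this read-out higher numbers stand for higher lipophilicity and lower numbers for lower lipophilicity), compound 1 gives -0.221, the lowest of the two numbers, while compound 2 gives 0.496, a gap beyond the scatter. Within the data shown here, no step between measured compounds that differ in one place is available. Compound 3 `Cc1ccc2c(c1)C=C(C(=O)N[C@@H]1O[C@H](CO)[C@@H](O)[C@H](O)[C@H]1O)C(=O)C2` differs from compound 1 by methyl in place of chloro on an aromatic carbon. In this assay this exchange is expected to change little, most likely slightly downward and within the scatter, so the step of a number 0.15 log units lower from compound 1 to compound 3 (within the scatter) is the expectation. Compound 3 is estimated at -0.37, in the range -0.75 to 0.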

Compound 3, partition coefficient: -0.451
The estimate for compound 3 lay 0.08 log units above the measured number; the range from low to high includes it.
By their numbers in this assay, from the lowest: compounds 3 and 1 (each within the scatter of the next); then compound 2.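

In this assay, within the data shown here, methyl in place of chloro on an aromatic carbon of the shared core gives a number 0.23 log units lower from compound 1 to compound 3 (within the scatter), the first one-place comparison. At this position, the read-out does not separate these two groups. No available measurement accounts for this result.

Going by these compounds, it remains open whether an amine or a carboxylic acid at this aromatic carbon would give a step beyond the scatter. Also open, on these data alone, is whether methyl in place of chloro would give a similar step on another core.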